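From dimethylamino to trifluoromethoxy on compound 1

This account rests on a few compounds, and the source may have more. Where it says the series, first, only, none or still open, it means among the compounds named here.

In a functional assay on PC-3 cells (Homo sapiens) for inhibition, read by sulforhodamine B assay (on this read-out lower numbers stand for stronger inhibition of growth and higher numbers for weaker inhibition of growth), compound 1 (`Cc1ccc2[nH]c(-c3ccc(-c4ccc(-c5ccc(N(C)C)cc5)cc4)cc3)nc2c1`) gives 8120 nM and shares the low end of the three numbers with compound 3 (`CN(C)c1ccc(-c2ccc(-c3ccc(-c4nc5c(O)cccc5[nH]4)cc3)cc2)cc1`), which gives 8420 nM and stays within the scatter of it. Compound 2 (`CN(C)c1ccc(-c2ccc(-c3ccc(-c4nc5ccccc5[nH]4)cc3)cc2)cc1`) gives 100000 nM and stands alone at the high end.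

Compound 4 (`Cc1ccc2[nH]c(-c3ccc(-c4ccc(-c5ccc(OC(F)(F)F)cc5)cc4)cc3)nc2c1`) keeps the core of compound 1 and carries trifluoromethoxy in place of dimethylamino on an aromatic carbon. For the measured compounds named here, none of the measured steps touches this group, since all three alter a different part of the molecule. The step of a 12-fold higher number from compound 1 to compound 2 (1.09 log units; beyond the scatter) is large and the step of a 12-fold lower number from compound 2 to compound 3 (1.07 log units; beyond the scatter) is large too, whereas the step of a 1.0-fold higher number from compound 1 to compound 3 (0.02 log units; within the scatter) stays within the scatter. These steps show how far the numbers can move among the three compounds, but they offer neither a size nor a direction for the new change. The estimate for this assay therefore stays anchored on compound 1 at 8120 nM with a wide margin. The expected step is a 1.1-fold higher number from compound 1 to compound 4 (0.04 log units; within the scatter) and no move beyond the scatter is predicted. Compound 4 is expected at 9000 nM within an estimated range of 2500 nM to 35000 nM on present evidence.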

Compound 4, concentration for 50% growth inhibition: 2010 nM
For compound 4 the middle estimate is 4.5-fold (0.65 log units) above the measured one; the measured number lies below the stated range.
By their numbers in this assay, from the lowest: compound 4; then compounds 1 and 3 (each within the scatter of the next); then compound 2.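

For the compounds shown here, the earlier compounds all kept dimethylamino and differed only at the other end of the molecule, so this pair is the first to show that the group on the aromatic carbon para to a large group also bears on the result in this assay. Trifluoromethoxy in place of dimethylamino gives a 4.0-fold lower number from compound 1 to compound 4 (0.61 log units; beyond the scatter), so the number can be moved beyond the scatter from this end of the shared core as well, although the step is modest beside the large ones seen at the other end. Nothing measured here accounts for the direction or size of this step.

With only these two groups shown at this position, it remains open whether a methoxy, a trifluoromethyl or a primary amine there would fall nearer compound 4 or compound 1. Going by these compounds, it is also open whether the same change from 4-(dimethylamino)phenyl to 4-(trifluoromethoxy)phenyl would give a step of similar size and direction on the core of compound 3, which has hydroxy where compound 1 has methyl.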